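Second Methyl on the Saturated Ring of Compound 2

The source may hold more compounds than are shown below. What is called first, only, known or untested is meant among the compounds shown, and "the series" means these compounds.

Measured compounds:
compound 1, `CC[C@H]1c2cc(Cl)ccc2C(=O)N1c1cncc2c1CCC[C@H]2NC(C)=O`, 97 nM
compound 2, `CC1CN(c2cccnc2)C(=O)c2ccc(Cl)cc21`, 164 nM
compound 3, `CCC(=O)N[C@@H]1CCCc2c1cncc2N1Cc2cc(Cl)ccc2C1=O`, 28 nM

In an assay on cells for inhibition of cytochrome P450 11B2, mitochondrial (Homo sapiens), read by HTRF (a lower number here means a stronger inhibitor, a higher number a weaker inhibitor), compound 2 gives 164 nM, the highest of the three numbers. Its nearest neighbour is compound 1, which gives 97 nM, a gap that stays within the usual scatter; the furthest is compound 3 with 28 nM, a gap that lies beyond it. Compound 2 thus sits at the weak end of this small set, though it cannot be separated from compound 1.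

Compound 4, `CC1(C)CN(c2cccnc2)C(=O)c2ccc(Cl)cc21`, is the next compound to be tested. It differs from compound 2 in one place: methyl in place of hydrogen on a saturated ring carbon. The change sits on a saturated ring carbon of the six-membered non-aromatic ring that carries the pyridin-3-yl group.

Among the compounds with values here, no step between measured compounds tells what such an exchange does in this assay, so nothing in the data points to a direction. The expected step from compound 2 to compound 4, a 1.0-fold lower number from compound 2 to compound 4 (0.01 log units; within the scatter), is therefore none beyond the scatter. Compound 4 is estimated at 160 nM, with a range from 55 nM to 480 nM.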

Compound 4, half-maximal inhibitory concentration: 1540 nM
Beside the measured number, compound 4's estimate is 9.6-fold (0.98 log units) below it; measured number above the stated range.
By their numbers in this assay, from the lowest: compound 3; then compounds 1 and 2 (each within the scatter of the next); then compound 4.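

Within the data shown here, this is the first step measured at this position, and it shows that the position is not indifferent to substitution: placing a second methyl on the saturated ring carbon, two ring bonds from the ring nitrogen, gives a 9.4-fold higher number from compound 2 to compound 4 (0.97 log units; beyond the scatter) in this assay. A change of a single carbon atom, with no hydrogen-bond donor, acceptor or charge added, is thus enough to move compound 4 clear of the other compounds shown. No measurement at hand accounts for this loss.

The compounds shown leave open how a hydroxyl group, a fluorine atom or an ethyl chain would behave in place of the added methyl on this carbon. They also leave open whether the same exchange would carry the same cost on the core of compound 3.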